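Thiophene amides: moving the ring attachment

The source may report more compounds than this note shows. Statements on the series, on what has been measured and on what is new or still open speak of the compounds shown alone.

Measured so far:
compound 1 `CCCCCCCCCCCC[C@@H](O)[C@H]1CC[C@H]([C@H](O)CCCCCCCCCCNC(=O)c2cccs2)O1` gives 2190 nM
compound 2 `CCCCCCCCCCCC[C@@H](O)[C@H]1CC[C@H]([C@H](O)CCCCCCCCCCNC(=O)c2cncs2)O1` gives 100000 nM

In a functional assay on MCF7 cells (Homo sapiens) for inhibition, read by colorimetric assay and sulforhodamine B assay, with a stated time of 48 h (a higher number here means a weaker inhibitor of growth, a lower number a stronger inhibitor of growth), compound 1 has the lower of the two numbers. Within the data shown here, the one measured step is a 46-fold higher number from compound 1 to compound 2 (1.66 log units; beyond the scatter) with 1,3-thiazol-5-yl in place of thiophen-2-yl on a carbonyl carbon, a large change beyond the scatter.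

Compound 3 `CCCCCCCCCCCC[C@@H](O)[C@H]1CC[C@H]([C@H](O)CCCCCCCCCCNC(=O)c2ccsc2)O1` is still unmeasured and has the same atoms as compound 1, joined differently: thiophen-3-yl in place of thiophen-2-yl on a carbonyl carbon on a carbonyl carbon.

Among the measured compounds shown here, only the step to compound 2 bears on this. It shows that this place can give a large step, but it also swaps in a different ring, whereas compound 3 keeps a thiophene. A much smaller step is therefore expected, most likely none beyond the scatter, with a slight lean to a higher number. The expected step is a 1.4-fold higher number from compound 1 to compound 3 (0.14 log units; within the scatter) in this assay as an estimate only. Compound 3 is estimated at 3000 nM with an expected range from 900 nM to 20000 nM in this series.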

Compound 3, concentration for 50% growth inhibition: 2000 nM
Compound 3: the middle estimate sits 1.5-fold (0.18 log units) above what was measured; the measured number falls inside the stated range.
By their numbers in this assay, from the lowest: compounds 3 and 1 (each within the scatter of the next); then compound 2.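

In this assay the change from thiophen-2-yl to thiophen-3-yl on the carbonyl carbon gives a 1.1-fold lower number from compound 1 to compound 3 (0.04 log units; within the scatter) and so leaves the reading unchanged within the scatter. Compound 2 now stands apart from both thiophene amides, with a 50-fold lower number from compound 2 to compound 3 (1.70 log units; beyond the scatter) as well as the earlier step, so across these compounds the large difference goes with 1,3-thiazol-5-yl and not with one thiophene attachment. No supporting data bear on the reason for this difference.

Open, from the compounds shown here alone, is whether the large step belongs to 1,3-thiazol-5-yl alone or would also appear with 1,3-thiazol-2-yl or pyridin-3-yl. Also open, going by these compounds, is whether this position would accept a chloro or methyl group on the thiophene, or a phenyl ring in its place.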